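This account rests on a few compounds, and the source may have more. Where it says the series, first, only, none or still open, it means among the compounds named here.

In a functional assay on A2780 cells (Homo sapiens) for inhibition, read by sulforhodamine B assay, with a stated time of 3 days (a higher number here means a weaker inhibitor, a lower number a stronger inhibitor), compound 1 (`O=C1Nc2ccc(F)cc2/C1=C\C(=O)c1cccs1`) gives 2750 nM and compound 2 (`O=C1Nc2ccc(F)cc2/C1=C\C(=O)c1cnc2ccc(Cl)nn12`) gives 2370 nM while compound 3 (`CN1CCN(c2cccc(N/C=C3\C(=O)Nc4ccc(NC(=O)c5c(F)cccc5F)cc43)c2)CC1`) gives 2030 nM on the same read-out. Compound 3 thus stands level with the other two. Its gaps to both lie within the scatter, so the three cannot be ranked.

Compound 4 (`CC(C)CC(=O)Nc1ccc2c(c1)/C(=C/Nc1cccc(N3CCN(C)CC3)c1)C(=O)N2`) differs from compound 3 in one place, with isobutyl in place of 2,6-difluorophenyl on a carbonyl carbon. Going by the values given here, no measured pair in this small set shows such an exchange, so the data offer no step to carry over. The expectation therefore starts from compound 3 at 2030 nM and foresees no shift beyond the scatter in this assay for this change. The estimated step (a 1.2-fold higher number from compound 3 to compound 4 (0.09 log units; within the scatter)) is accordingly small, although with so little to go on the expectation remains loose. For compound 4 the estimated value is 2500 nM with an expected range from 800 nM to 8000 nM when it is measured.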

Compound 4, half-maximal inhibitory concentration: 3370 nM
Beside the measured number, compound 4's estimate is 1.3-fold (0.13 log units) below it, and the stated range covers the measured number.
By their numbers in this assay, from the lowest: compounds 3, 2, 1 and 4 (each within the scatter of the next).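

Going by these compounds alone, exchanging the 2,6-difluorophenyl on the carbonyl carbon for isobutyl gives a 1.7-fold higher number from compound 3 to compound 4 (0.22 log units; within the scatter) in this assay, the only single-place comparison in this set. Since this step lies within the scatter, a group with no ring at this place cannot be told apart from the aromatic ring it replaces, so the ring is not shown to matter for this read-out. No measurement here bears on why the two groups read alike.

The compounds shown leave open whether an amine, a carboxylic acid or a longer chain on this carbonyl carbon would move the number beyond the scatter, and whether an unsubstituted phenyl would differ from the 2,6-difluorophenyl. Going by these compounds, with a single pair, it also remains open whether this exchange would behave the same way on another core.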